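The source may report more compounds than this note shows. Statements on the series, on what has been measured and on what is new or still open speak of the compounds shown alone.

In a functional assay on MIA PaCa-2 cells (Homo sapiens) for inhibition, read by MTT assay, with a stated time of 3 days (on this read-out lower numbers stand for stronger inhibition and higher numbers for weaker inhibition), compound 3 `CCN(CC)S(=O)(=O)c1ccc(S(=O)(=O)N2CCC[C@@H](C(=O)NC3CCOCC3)C2)cc1` gives 1350 nM, the highest of the three numbers recorded. Compound 1 `CCN(CC)S(=O)(=O)c1ccc(S(=O)(=O)N2CCC[C@@H](C(=O)N3CC[C@@H](OC)C3)C2)cc1` gives 1070 nM, and the step of a 1.3-fold higher number from compound 1 to compound 3 (0.10 log units; within the scatter) lies within the scatter. Compound 2 `CCN(CC)S(=O)(=O)c1ccc(S(=O)(=O)N2CCC[C@@H](C(=O)N3CCC(OC)CC3)C2)cc1` gives 50 nM, and that comparison shows a 27-fold higher number from compound 2 to compound 3 (1.43 log units; beyond the scatter). Compound 4 `CCN(CC)S(=O)(=O)c1ccc(S(=O)(=O)N2CCC[C@@H](C(=O)N[C@H]3CCOC3)C2)cc1` differs from compound 3 in one place: oxolan-3-yl in place of oxan-4-yl on an amide-type nitrogen. Going by the values given here, no measured step alters the ring on the amide-type nitrogen directly. The nearest comparison is a 21-fold lower number from compound 1 to compound 2 (1.33 log units; beyond the scatter), where 4-methoxypiperidin-1-yl in place of 3-methoxypyrrolidin-1-yl on the carbonyl carbon lowered the number sharply; read in reverse, a smaller ring in place of a larger one raised it. That comparison concerns groups joined to the carbonyl carbon, not the (oxan-4-yl)amino group of compound 3, so it guides only loosely. A step of a 1.9-fold higher number from compound 3 to compound 4 (0.27 log units; within the scatter) is therefore expected, in the upward direction, if any beyond the scatter. Compound 4 is estimated at 2500 nM, with a range from 800 nM to 8000 nM.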

Compound 4, half-maximal inhibitory concentration: 290 nM
Compound 4: middle estimate off by 8.6-fold (0.94 log units), on the high side, outside the stated range (below it).
By their numbers in this assay, from the lowest: compound 2; then compound 4; then compounds 1 and 3 (each within the scatter of the next).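

On the amide-type nitrogen, oxolan-3-yl in place of oxan-4-yl gives a 4.7-fold lower number from compound 3 to compound 4 (0.67 log units; beyond the scatter) in this assay, so the five-membered ring lowers the number at this position, whereas the five-membered group on the carbonyl carbon carried the higher number in a 21-fold lower number from compound 1 to compound 2 (1.33 log units; beyond the scatter). The ring change on the carbonyl carbon therefore does not carry over to this change on the amide-type nitrogen, and (oxolan-3-yl)amino takes a middle place among the groups on the carbonyl carbon, with a 3.7-fold lower number from compound 1 to compound 4 (0.57 log units; beyond the scatter) on one side and a 5.8-fold higher number from compound 2 to compound 4 (0.76 log units; beyond the scatter) on the other. Nothing available here explains this difference in direction.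

The compounds shown leave open how the other stereoisomer of oxolan-3-yl would compare with compound 4. They also leave open what an oxetan-3-yl ring or a pyrrolidin-3-yl amine would do on the same nitrogen.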